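The compounds below may be only part of what the source reports. "The series", "measured", "known", "first", "only" and "open" are said of these compounds alone.

In a functional assay on THP-1 cells (Homo sapiens) for cytotoxicity, read by MTT assay, with a stated time of 24 h (a lower number here means a stronger inhibitor, a higher number a weaker inhibitor), compound 1 (`CN1C/C(=C\c2ccc(C(C)(C)C)cc2)C(=O)/C(=C/c2ccccc2F)C1`) gives 13400 nM and compound 2 (`COc1cc(/C=C2\CN(C)C/C(=C\c3ccc(F)cc3)C2=O)cc(OC)c1`) gives 5040 nM while compound 3 (`COc1cc(/C=C2\CN(C)C/C(=C\c3ccc(F)cc3)C2=O)cc(OC)c1OC`) gives 6130 nM and so stands within the scatter of compound 2, with the number of compound 1 higher than both. Compound 4 (`COc1cc(/C=C2\CN(C)C/C(=C\c3ccc(C#N)cc3)C2=O)cc(OC)c1OC`) differs from compound 3 in one place, with cyano in place of fluoro on an aromatic carbon, para to a large group (cyano in place of fluoro on an aromatic carbon). Among the measured compounds shown here, only one measured step links two compounds that differ in one place: a 1.2-fold higher number from compound 2 to compound 3 (0.09 log units; within the scatter) for methoxy in place of hydrogen on an aromatic carbon. That step lies within the scatter, but it does not touch the fluoro group, so it bears on the change only indirectly. For the measured compounds named here, no measured step covers a swap of fluoro for cyano. The expectation in this assay is therefore no step beyond the scatter, in either direction, though with a wide margin. For compound 4 the expected value is 5500 nM (estimated range 2200 nM to 13000 nM).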

Compound 4, half-maximal inhibitory concentration: 820 nM
Compound 4: the middle estimate sits 6.7-fold (0.83 log units) above what was measured, outside the stated range (below it).
By their numbers in this assay, from the lowest: compound 4; then compounds 2 and 3 (each within the scatter of the next); then compound 1.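

Cyano in place of fluoro, on an aromatic carbon para to a large group, gives (a 7.5-fold lower number from compound 3 to compound 4 (0.87 log units; beyond the scatter)) in this assay. Among the compounds shown here, this shows that the number is sensitive to the group at this position, a sensitivity that the one earlier step, methoxy in place of hydrogen on an aromatic carbon (a 1.2-fold higher number from compound 2 to compound 3 (0.09 log units; within the scatter)), did not reveal because it stayed within the scatter and did not touch this position. No measurement on these compounds gives a reason for the new step.

From the compounds shown here alone, the change is seen only once, on the background of compound 3, so whether it carries over to compound 2 remains open. Also open, going by these compounds, is how other groups at this position, such as a carboxylic acid, an amine or trifluoromethyl, would compare with cyano.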